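The source may hold more compounds than are shown below. What is called first, only, known or untested is meant among the compounds shown, and "the series" means these compounds.

Of the compounds shown here, three sharing one core have been tested in a functional assay on MDA-MB-231 cells (Homo sapiens) for antiproliferative activity, with a stated time of 4 days; a lower number here means a stronger inhibitor, a higher number a weaker inhibitor. Compound 1 `CCCCc1ccc2[nH]c(-c3ccc(OC)cc3)c(C=O)c2c1` gives 6.7 nM, compound 2 `CCCCc1ccc2[nH]c(-c3ccc(CC)cc3)c(C=O)c2c1` gives 27 nM, and compound 3 `CCCCc1ccc2[nH]c(-c3ccc(C(F)(F)F)cc3)c(C=O)c2c1` gives 33 nM. The data show a 1.2-fold higher number from compound 2 to compound 3 (0.09 log units; within the scatter), which is within the scatter, so compound 3 stands level with compound 2. Against compound 1, they show a 4.9-fold higher number from compound 1 to compound 3 (0.69 log units; beyond the scatter), and this lies beyond the scatter, as does a 4.0-fold higher number from compound 1 to compound 2 (0.61 log units; beyond the scatter).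

Compound 4 `CCCCCCc1ccc2[nH]c(-c3ccc(C(F)(F)F)cc3)c(C=O)c2c1` keeps the trifluoromethyl group and differs only in its saturated chain, with ethyl in place of hydrogen on a saturated chain carbon, four bonds along the chain from an aromatic carbon. Within the data shown here, no measured step changes this chain. All three alter the other group, on an aromatic carbon, so they bear on the new step only indirectly, showing that one change in this series can shift the number modestly. With no direct evidence, the direction is uncertain, and only a small rise in this assay, within the scatter, is expected. This estimate amounts to a 1.5-fold higher number from compound 3 to compound 4 (0.18 log units; within the scatter). For compound 4 the expected value is 50 nM, within an estimated range of 12 nM to 200 nM.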

Compound 4, half-maximal inhibitory concentration: 43 nM
For compound 4 the middle estimate is 1.2-fold (0.07 log units) above the measured one; low and high end bracket the measured number.
By their numbers in this assay, from the lowest: compound 1; then compounds 2, 3 and 4 (each within the scatter of the next).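

In this assay, among these compounds, this is the first direct reading of the saturated chain: a 1.3-fold higher number from compound 3 to compound 4 (0.11 log units; within the scatter), so ethyl in place of hydrogen at this chain carbon leaves the compound level with its parent. The earlier steps shown here all concerned the group on an aromatic carbon, where the one from methoxy to trifluoromethyl, a 4.9-fold higher number from compound 1 to compound 3 (0.69 log units; beyond the scatter), went beyond the scatter; here, on this trifluoromethyl background, the chain accepts two more carbons with no readable shift. No measurement shown accounts for this result.

Going by these compounds, whether the same chain change would also leave the number level with methoxy on the aromatic carbon, as in compound 1, stays open. On these data alone, how a still longer chain, or a chain ending in an amine or a carboxylic acid, would behave at this position also remains unknown.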